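This account rests on a few compounds, and the source may have more. Where it says the series, first, only, none or still open, it means among the compounds named here.

Measured in an assay on isolated protein for inhibition of Rho-associated protein kinase 1 (Homo sapiens), read by scintillation counting, radiometric assay and 33P incorporation, with a stated time of 40 min, in the presence of a further agent that is not named here; on this read-out higher numbers stand for weaker inhibition and lower numbers for stronger inhibition:
- compound 1 `O=C(COc1ccc2c(=O)ccoc2c1)Nc1cccc(NC(=O)c2ccc(Br)cc2)c1`: 303 nM
- compound 2 `CCOc1ccc(C(=O)Nc2cccc(NC(=O)COc3ccc4c(=O)ccoc4c3)c2)cc1`: 17 nM
- compound 3 `COC(=O)c1ccc(C(=O)Nc2cccc(NC(=O)COc3ccc4c(=O)ccoc4c3)c2)cc1`: 72 nM

Compound 3 holds the second highest of the three numbers: it sits a 4.2-fold lower number from compound 1 to compound 3 (0.62 log units; beyond the scatter) and a 4.2-fold higher number from compound 2 to compound 3 (0.63 log units; beyond the scatter). All three compounds share one core and differ only in the group on the terminal aromatic ring.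

Compound 4 `Nc1ccc(C(=O)Nc2cccc(NC(=O)COc3ccc4c(=O)ccoc4c3)c2)cc1` continues that single-point variation: amino in place of methoxycarbonyl on an aromatic carbon.

For the measured compounds named here, the steps that bear on it are the three substitutions at the same carbon: an 18-fold lower number from compound 1 to compound 2 (1.25 log units; beyond the scatter), a 4.2-fold lower number from compound 1 to compound 3 (0.62 log units; beyond the scatter) and a 4.2-fold higher number from compound 2 to compound 3 (0.63 log units; beyond the scatter). Going by the values given here, this position clearly moves the numbers, by modest to large amounts, and no measured compound carries a group resembling amino. Ethoxy gave the lowest number and bromo the highest, with methoxycarbonyl between. A step of modest size is therefore expected in this assay, more likely downward than upward, but with wide uncertainty.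

Compound 4 is estimated at 40 nM (range 12 nM to 150 nM), an expected 1.8-fold lower number from compound 3 to compound 4 (0.26 log units; within the scatter).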

Compound 4, half-maximal inhibitory concentration: 802 nM
Compound 4: the middle estimate sits 20-fold (1.30 log units) below what was measured, and the stated range ends below it.
By their numbers in this assay, from the lowest: compound 2; then compound 3; then compound 1; then compound 4.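

In this assay, amino on this carbon, para to a large group, is the weakest of the four groups: an 11-fold higher number from compound 3 to compound 4 (1.05 log units; beyond the scatter), a 47-fold higher number from compound 2 to compound 4 (1.67 log units; beyond the scatter) and a 2.6-fold higher number from compound 1 to compound 4 (0.42 log units; beyond the scatter). Bromo therefore no longer marks the weak end at this carbon, and the span of the series now runs from ethoxy to amino, with the exchange of methoxycarbonyl for amino adding a hydrogen-bond donor and removing a double bond outside aromatic rings. No measurement available here accounts for this loss.

Whether the amide hydrogen-type donor of amino matters cannot be separated from the other differences with one compound, and a dimethylamino or acetamido group on the same carbon would bear on that. From the compounds shown here alone, it also remains open whether the low number of ethoxy holds for methoxy or a longer chain such as propoxy.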